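This account rests on a few compounds, and the source may have more. Where it says the series, first, only, none or still open, it means among the compounds named here.

In a functional assay on the whole organism with Mus musculus as the target (a lower number here means that less compound is needed, a higher number that more compound is needed for the effect), compound 3 `CC(N)c1nnc(-c2ccccc2-c2ccccc2)s1` gives 21 mg/kg. No other compound shown gives a lower number, yet compound 1 `CC(C)NCc1nnc(-c2ccccc2-c2ccccc2)s1`, with 23 mg/kg, sits within the scatter of it, and only compound 2 `NCc1nnc(Cc2ccccc2)s1`, with 110 mg/kg, lies clearly apart. Compound 4 `NCCCc1nnc(-c2ccccc2-c2ccccc2)s1` differs from compound 3 in one place: 3-aminopropyl in place of 1-aminoethyl on an aromatic carbon. For the measured compounds named here, no measured step changes the length of this chain. Going by the values given here, the one step measured, a 1.1-fold lower number from compound 1 to compound 3 (0.04 log units; within the scatter), swapped the group on that aromatic carbon and stayed flat, so there is little ground to expect a large move from lengthening the chain. A small step is therefore expected, a 1.2-fold higher number from compound 3 to compound 4 (0.08 log units; within the scatter). For compound 4 the expected value is 25 mg/kg, within a range from 10 mg/kg to 65 mg/kg.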

Compound 4, dose for half-maximal effect: > 200 mg/kg
Compound 4: no number, only a limit; the forecaster's own chance of this, stated with the estimate: 5%; middle value at least 8.0-fold (0.90 log units) away from the limit.
By their numbers in this assay, from the lowest: compounds 3 and 1 (each within the scatter of the next); then compound 2. At a limit, above all of these: compound 4.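

For compound 4 the result in this assay is a limit and not a number: the limit of > 200 mg/kg in this assay, at which 1 of the 4 values shown sits. With 3-aminopropyl in place of 1-aminoethyl on an aromatic carbon, the data show an at least 9.5-fold higher number from compound 3 to compound 4 (0.97 log units; beyond the scatter), so this position, flat in the earlier step, does respond to the group it carries. The comparison with the other amine gives a similar picture, with an at least 8.6-fold higher number from compound 1 to compound 4 (0.93 log units; beyond the scatter).

On these data alone, whether the rise follows chain length alone or the branching of 1-aminoethyl stays open. 2-Aminoethyl and 1-aminopropyl on that aromatic carbon would tell these apart.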